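Swapping chloro for hydroxy on the aryl ring of compound 1

The source may report more compounds than this note shows. Statements on the series, on what has been measured and on what is new or still open speak of the compounds shown alone.

Compound 1 `CCCS(=O)(=O)Nc1ccc(F)c(C(=O)c2n[nH]c3ncc(-c4ccccc4Cl)cc23)c1F` is tested in an assay for binding affinity to dual specificity mitogen-activated protein kinase kinase 4 (Homo sapiens), read by KINOMEscan, tested at 100 nM (a lower number here means a stronger effect, a higher number a weaker effect of the compound at the concentration tested), where compound 1 gives 9.3%. Compound 2 `CCCS(=O)(=O)Nc1ccc(F)c(C(=O)c2n[nH]c3ncc(-c4ccc(C)cc4)cc23)c1F` gives 5.4% and compound 3 `CCCS(=O)(=O)Nc1ccc(F)c(C(=O)c2n[nH]c3ncc(-c4ccccc4OC)cc23)c1F` gives 1.9%; the step of a number 3.9 percentage points lower from compound 1 to compound 2 (within the scatter) and the step of a number 7.4 percentage points lower from compound 1 to compound 3 (within the scatter) both leave compound 1 within the scatter of its two neighbours. Compound 4 `CCCS(=O)(=O)Nc1ccc(F)c(C(=O)c2n[nH]c3ncc(-c4ccccc4O)cc23)c1F` is not yet measured. It differs from compound 1 in one place: hydroxy in place of chloro on an aromatic carbon. The step of a number 7.4 percentage points lower from compound 1 to compound 3 (within the scatter), which exchanges the same chloro at the same place, bears most directly on this change and stayed within the scatter, so no step beyond the scatter is expected here. Compound 4 is therefore expected to give about 5% in this assay, between 1% and 15%, an estimated step of a number 4.3 percentage points lower from compound 1 to compound 4 (within the scatter).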

Compound 4, a percentage reported as activity, at one concentration (the size of the read-out at that concentration, not a potency): 9%
Beside the measured number, compound 4's estimate is 4 percentage points below it; the range from low to high includes it.
By their numbers in this assay, from the lowest: compounds 3, 2, 4 and 1 (each within the scatter of the next).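

In this assay, hydroxy on this aromatic carbon, which adds a hydrogen-bond donor that chloro lacks, stays within the scatter of chloro (a number 0.3 percentage points lower from compound 1 to compound 4 (within the scatter)). The same holds for hydrogen in place of methyl on the oxygen (a number 7.1 percentage points higher from compound 3 to compound 4 (within the scatter)) and for the comparison with 4-methylphenyl (a number 3.6 percentage points higher from compound 2 to compound 4 (within the scatter)), so the donor shows no readable effect here. Nothing measured offers an explanation for this. Going by these compounds, whether an amine, a carboxylic acid or a longer chain such as ethoxy at this place would step beyond the scatter stays open. A single concentration also leaves any potency differences among these compounds unresolved.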